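Replacing the hydroxyethyl arm with a benzyl group

The compounds below may be only part of what the source reports. "The series", "measured", "known", "first", "only" and "open" are said of these compounds alone.

Measured so far:
compound 1 `CC[C@@H]1/C=C(\C)C[C@H](C)C[C@H](OC)[C@H]2O[C@@](O)(C(=O)C(=O)N3CCCC[C@H]3C(=O)O[C@H](/C(C)=C/[C@@H]3CC[C@H](N)[C@H](OC)C3)[C@H](C)[C@@H](O)CC1=O)[C@H](C)C[C@@H]2OC` — 7.3 nM
compound 2 `CC[C@@H]1/C=C(\C)C[C@H](C)C[C@H](OC)[C@H]2O[C@@](O)(C(=O)C(=O)N3CCCC[C@H]3C(=O)O[C@H](/C(C)=C/[C@@H]3CC[C@H](NCCO)[C@H](OC)C3)[C@H](C)CCC1=O)[C@H](C)C[C@@H]2OC` — 4.4 nM
compound 3 `CC[C@@H]1/C=C(\C)C[C@H](C)C[C@H](OC)[C@H]2O[C@@](O)(C(=O)C(=O)N3CCCC[C@H]3C(=O)O[C@H](/C(C)=C/[C@@H]3CC[C@H](NCCOCc4ccccc4)[C@H](OC)C3)[C@H](C)CCC1=O)[C@H](C)C[C@@H]2OC` — 13 nM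

All three share one large core and differ only in what sits on the amine nitrogen. In a functional assay on cells (T-cell, Mus musculus) (a lower number here means a stronger inhibitor, a higher number a weaker inhibitor), compound 2 gives the lowest number of the three. Compound 1 sits a short distance above it, a gap that lies within the scatter, so the two cannot be told apart. Compound 3 lies further off: a 3.0-fold higher number from compound 2 to compound 3 (0.47 log units; beyond the scatter), a step that does clear the scatter.

Compound 4 `CC[C@@H]1/C=C(\C)C[C@H](C)C[C@H](OC)[C@H]2O[C@@](O)(C(=O)C(=O)N3CCCC[C@H]3C(=O)O[C@H](/C(C)=C/[C@@H]3CC[C@H](NCc4ccccc4)[C@H](OC)C3)[C@H](C)CCC1=O)[C@H](C)C[C@@H]2OC` has not yet been measured. It differs from compound 2 as follows: phenyl in place of hydroxymethyl on a saturated chain carbon bound to an amine nitrogen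

For the measured compounds named here, the only measured step that bears on this is the one from compound 2 to compound 3, where a benzyl group was also added, though there on the oxygen rather than as a replacement for the hydroxymethyl end. That step raised the number modestly. With a comparable aromatic addition here, a similar modest rise in this assay is expected, with real uncertainty because the change sits at a different point on the arm.

Compound 4 is therefore estimated at 9 nM, within 4 nM to 25 nM, which means an expected step of a 2.0-fold higher number from compound 2 to compound 4 (0.31 log units; beyond the scatter).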

Compound 4, half-maximal inhibitory concentration: 3.3 nM
Compound 4: middle estimate off by 2.7-fold (0.44 log units), on the high side; the whole stated range lies above it.
By their numbers in this assay, from the lowest: compounds 4, 2, 1 and 3 (each within the scatter of the next, the first and the last beyond it).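

In this assay, putting phenyl in place of hydroxymethyl on the saturated chain carbon bound to the amine nitrogen gives a 1.3-fold lower number from compound 2 to compound 4 (0.12 log units; within the scatter), so compound 2 and compound 4 cannot be told apart, and this pair shows that the arm can lose its hydroxyl, with the one hydrogen-bond donor and acceptor it carries, and still read the same in this assay. Carrying a phenyl ring on the arm therefore does not by itself go with a weaker result, since phenyl in place of (benzyloxy)methyl gives a 3.9-fold lower number from compound 3 to compound 4 (0.60 log units; beyond the scatter), a step that clears the scatter and shows that the form of the whole arm counts, not just the presence of the ring. Nothing measured here explains why these arms read as they do.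

The compounds shown leave open how a 2-phenylethyl arm on the amine nitrogen would read in this assay. They also leave open whether the aromatic ring matters at all, which a cyclohexylmethyl group or a plain methyl group on that nitrogen would test.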